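Swapping the amide amine back toward a smaller ring

The compounds below may be only part of what the source reports. "The series", "measured", "known", "first", "only" and "open" are said of these compounds alone.

Compound 2 `COc1ccc(OC)c(-c2cc(-c3ccc(C(=O)N(C)Cc4ccc(F)cc4)s3)on2)c1` sits at the edge of what a functional assay on A549 cells (Homo sapiens) for cytotoxicity, read by XTT assay, with a stated time of 72 h (a higher number here means a weaker inhibitor, a lower number a stronger inhibitor), can report: its value of > 30000 nM is only a limit, not a number, (the limit of > 30000 nM in this assay, at which 1 of the 2 values shown sits). Compound 1 `CCN(CC)C(=O)c1ccc(-c2cc(-c3cc(OC)ccc3OC)no2)s1`, with diethylamino on the carbonyl carbon, gives 11000 nM in this assay, and the step of an at least 2.7-fold higher number from compound 1 to compound 2 (0.43 log units; beyond the scatter) weakened it. Compound 3 `COc1ccc(OC)c(-c2cc(-c3ccc(C(=O)N4CCCCC4)s3)on2)c1` changes (piperidin-1-yl in place of (4-fluorobenzyl)(methyl)amino on a carbonyl carbon). For compound 3 a step toward a lower number, an at least 2.0-fold lower number from compound 2 to compound 3 (0.30 log units; that floor lies within the scatter), is expected because compound 1 with diethylamino on the carbonyl carbon gave 11000 nM. Compound 3 is estimated at 15000 nM, between 6000 nM and 40000 nM.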

Compound 3, half-maximal inhibitory concentration: > 30000 nM
Compound 3 was reported as a limit; the forecaster's own chance of this, stated with the estimate: 35%; at least 2.0-fold (0.30 log units) between middle value and limit.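

Piperidin-1-yl on the carbonyl carbon gives an at least 2.7-fold higher number from compound 1 to compound 3 (0.43 log units; beyond the scatter) in this assay, so losing the benzyl ring of compound 2 does not bring back the readable value of compound 1. Compound 3 is reported only as a limit, as is compound 2, so the step between them cannot be read. Of the three amides, only the diethylamino one has a readable value, and the other two share one ceiling: the limit of > 30000 nM in this assay, at which 2 of the 3 values shown sit.

From the compounds shown here alone, whether pyrrolidine or morpholine on the carbonyl carbon would give a readable value remains open. So does how far compound 2 and compound 3 lie beyond their limits.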